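From compound 3 to compound 4: a larger side group

This account rests on a few compounds, and the source may have more. Where it says the series, first, only, none or still open, it means among the compounds named here.

Compound 3 `N/C(S)=N/CCCCn1nc(-c2ccccc2)ccc1=O` carries on its chain a group of 4 heavy atoms (1 carbon, 2 nitrogen, 1 sulfur; no ring). In a functional assay on the whole organism with Rattus norvegicus as the target, at a dose of 100 mg/kg (on this read-out lower numbers stand for less inhibition and higher numbers for more inhibition at the one dose given (going by the name of the read-out)), compound 3 gives 72%, the second highest of three numbers: compound 1 `CN(C)/C(=N/CCCCn1nc(-c2ccccc2)ccc1=O)NC#N` gives 80.7% and compound 2 `C/N=C(\S)NCCCCCn1nc(-c2ccccc2)ccc1=O` gives 68.9%, both within the scatter of compound 3. Compound 4 `C/N=C(/NC#N)N(C)CCCCn1nc(-c2ccccc2)ccc1=O` has not been measured; it differs from compound 3 in one place: a group of 8 heavy atoms (4 carbon, 4 nitrogen; no ring) in place of a group of 4 heavy atoms (1 carbon, 2 nitrogen, 1 sulfur; no ring), on a saturated chain carbon, four bonds along the chain from an aromatic nitrogen. The closest guide is the step of a number 8.7 percentage points lower from compound 1 to compound 3 (within the scatter), which exchanges the same two group sizes in the reverse direction; the step of a number 3.1 percentage points higher from compound 2 to compound 3 (within the scatter) also stayed within the scatter. A step no larger than the scatter is therefore expected, a number 6 percentage points higher from compound 3 to compound 4 (within the scatter). Compound 4 is estimated at 78%, between 63% and 90%.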

Compound 4, a percentage reported as inhibition, in the whole organism at one dose (the size of the read-out at that dose, not a potency): 27%
Beside the measured number, compound 4's estimate is 51 percentage points above it; measured number outside the range, below it.
By their numbers in this assay, from the lowest: compound 4; then compounds 2, 3 and 1 (each within the scatter of the next, the first and the last beyond it).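

At this chain position, this assay responds sharply to the group: the number comes out a number 45 percentage points lower from compound 3 to compound 4 (beyond the scatter) and a number 41.9 percentage points lower from compound 2 to compound 4 (beyond the scatter) once the larger group enters. Size alone does not settle it, for a swap between two groups with the same heavy atoms, differently arranged, gives a number 53.7 percentage points lower from compound 1 to compound 4 (beyond the scatter) in the same read-out. Nothing measured here explains this drop.

Still open, from the compounds shown here alone, is how a simple amine or a urea would behave at this place, and whether a longer chain carrying the group of compound 4 would restore the higher numbers.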